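Replacing tert-butyl with methyl in a growth inhibitor

The source may hold more compounds than are shown below. What is called first, only, known or untested is meant among the compounds shown, and "the series" means these compounds.

Compound 1 `O=C(CCl)NC(=O)Nc1ccc(OC2CCCCC2)cc1`: 4700 nM 
Compound 2 `CC(C)(C)c1ccc(NC(=O)NC(=O)CCl)cc1`: 4800 nM 

In a functional assay on MCF7 cells (Homo sapiens) for inhibition, read by sulforhodamine B assay, with a stated time of 48 h (a higher number here means a weaker inhibitor of growth, a lower number a stronger inhibitor of growth), compound 2 gives 4800 nM and sits level with compound 1, whose 4700 nM lies within the scatter of it. With only these two numbers, neither compound can be ranked above the other.

The next compound, compound 3 `Cc1ccc(NC(=O)NC(=O)CCl)cc1`, keeps the shared core but has methyl in place of tert-butyl on an aromatic carbon. Among the compounds with values here, one measured step bears on this change. In it, tert-butyl took the place of cyclohexyloxy on an aromatic carbon, and a 1.0-fold higher number from compound 1 to compound 2 (0.01 log units; within the scatter) stayed within the scatter. Two different groups at this carbon therefore gave matching numbers in this assay for these two compounds. However, no compound with methyl there has been measured, and a single step is thin evidence, so the range must stay wide.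

The expected change is small, with a 1.3-fold higher number from compound 2 to compound 3 (0.10 log units; within the scatter) as the estimated step and no clear move beyond the scatter anticipated. For compound 3 the estimated value is 6000 nM, with an expected range from 2500 nM to 14000 nM.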

Compound 3, concentration for 50% growth inhibition: 7500 nM
Estimate against measurement, compound 3: 1.3-fold (0.10 log units) below, and the stated range covers the measured number.
By their numbers in this assay, from the lowest: compounds 1, 2 and 3 (each within the scatter of the next).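

Going from tert-butyl, with 4 heavy atoms, to methyl, with 1 heavy atom, on this aromatic carbon is a large cut in the size of the group, yet in this assay the step is only (a 1.6-fold higher number from compound 2 to compound 3 (0.19 log units; within the scatter)). Replacing cyclohexyloxy with methyl at the same carbon gives a similar picture (a 1.6-fold higher number from compound 1 to compound 3 (0.20 log units; within the scatter)), so the three groups now tested here give numbers that cannot be told apart, even though one of them is a single carbon. No measurement is available to explain why these groups give such similar numbers.

An amine or a carboxylic acid on this carbon would show whether this tolerance extends beyond the three groups seen so far, which the compounds shown cannot tell. The rest of the structure is also the same in all three compounds, so these numbers say nothing about how growth inhibition responds to changes elsewhere in the shared core.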